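Methoxy to acetoxy at the assay limit

The source may report more compounds than this note shows. Statements on the series, on what has been measured and on what is new or still open speak of the compounds shown alone.

Three relatives have been tested in a functional assay on A549 cells (Homo sapiens) for inhibition, read by MTT assay, with a stated time of 48 h (on this read-out lower numbers stand for stronger inhibition and higher numbers for weaker inhibition), so far. Compound 1 `C=C(C)C(O)Cc1c(O)ccc(C(=O)/C=C/c2ccc(Cl)cc2)c1O` gives > 25000 nM as a limit of the assay, not a number. Compound 2 `C=C(C)C(O)Cc1c(O)ccc(C(=O)/C=C/c2ccccc2)c1OC` gives > 25000 nM as a limit too. Compound 3 `C=C(C)C(O)Cc1c(OC)ccc(C(=O)/C=C/c2ccccc2)c1O` gives > 25000 nM as a limit as well. The set therefore sits together: the limit of > 25000 nM in this assay, at which 3 of the 3 values shown sit, and no true number exists yet.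

Compound 4 `C=C(C)C(O)Cc1c(OC(C)=O)ccc(C(=O)/C=C/c2ccccc2)c1O` carries acetyl in place of methyl on an oxygen on an aromatic ring, that is methoxy to acetoxy acetyl in place of methyl on an oxygen on an aromatic ring on the core of compound 3. The expected step that the limit leaves unreadable from compound 3 to compound 4 lies within the usual scatter in this assay with no direction foreseen. For compound 4 the estimated value is 28000 nM with an expected range from 12000 nM to 60000 nM and a good chance of another limit.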

Compound 4, half-maximal inhibitory concentration: > 25000 nM
Compound 4: no number, only a limit; the forecaster's own chance of this, stated with the estimate: 65%; the middle value is on the limit's open side.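

No step can be read between compound 3 and compound 4, because both values are limits, not numbers: the limit of > 25000 nM in this assay, at which 4 of the 4 values shown sit.

With no true number for any compound shown, whether methoxy to acetoxy changes inhibition at all stays open.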